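Swapping the hydrazone aryl group: compound 2 to compound 3

A few compounds are considered here, and "the series" means these few. Any claim that something is new, unique, unknown or untested is made for them only; others in the source may bear on it.

Measured compounds:
- compound 1, `COc1cc2c(Oc3ccc(NC(=O)N/N=C/c4ccc(N(C)C)cc4)cc3F)ccnc2cc1OCCCN1CCCCC1`, a functional assay on A549 cells (Homo sapiens) for cytotoxicity, read by MTT assay, with a stated time of 72 h; a lower number here means a stronger inhibitor, a higher number a weaker inhibitor: "not determined" (no result reported)
- compound 2, `C=CCc1cccc(/C=N/NC(=O)Nc2ccc(Oc3ccnc4cc(OCCCN5CCCCC5)c(OC)cc34)c(F)c2)c1OC`, this assay: 250 nM

Two compounds share a common core, and one of them carries a number. Compound 1 has no reported result in this assay, so it offers no point of comparison. Going by the values given here, compound 2 is therefore the only compound with a value here, giving 250 nM in this assay, and it stands alone rather than at the top or bottom of any ranking.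

Compound 3, `COc1cc2c(Oc3ccc(NC(=O)N/N=C/c4cc5ccccc5[nH]4)cc3F)ccnc2cc1OCCCN1CCCCC1`, has not yet been measured. It differs from compound 2 in one place: 1H-indol-2-yl in place of 3-allyl-2-methoxyphenyl on a carbon with a double bond to nitrogen. In plain words, the aryl group attached to the hydrazone carbon is exchanged for an indole, and the methoxy and allyl substituents of compound 2 leave with it.

Among the compounds with values here, no measured pair shows what such an exchange does to this assay, so the expectation rests on compound 2 alone. The change is expected to cost little or nothing beyond the usual scatter, with a step of a 1.6-fold higher number from compound 2 to compound 3 (0.20 log units; within the scatter) estimated. Compound 3 is expected to give about 400 nM, within a range from 100 nM to 1600 nM.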

Compound 3, half-maximal inhibitory concentration: 780 nM
The estimate for compound 3 lay 2.0-fold (0.29 log units) below the measured number; measured number inside the range.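

In this assay, going by these compounds alone, the group on the carbon with a double bond to nitrogen clearly matters: placing 1H-indol-2-yl there instead of 3-allyl-2-methoxyphenyl gives a 3.1-fold higher number from compound 2 to compound 3 (0.49 log units; beyond the scatter), the first measured step at this position. This single exchange changes several things at once, since the allyl and methoxy groups leave, a five-membered aromatic ring enters, and one hydrogen-bond acceptor gives way to one hydrogen-bond donor, so the step belongs to the whole swap and not to any one of these features. No measurement shown here explains why the number rises.

On these data alone, it remains open whether the allyl group, the methoxy group or both set compound 2 apart from compound 3, and whether the hydrogen-bond donor of the indole plays any part in the difference. A plain phenyl group, a phenyl carrying only methoxy or only allyl, or a pyridyl group on the same carbon would help to separate these possibilities, and a carboxylic acid or an amine on the ring would test a wider range of substituents.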